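From Compound 1 to Compound 4: One Group Exchanged

The compounds below may be only part of what the source reports. "The series", "measured", "known", "first", "only" and "open" are said of these compounds alone.

Measured so far:
compound 1, `CCOC(=O)c1ccc(NC(=O)N2CC2C#N)cc1`: 9700 nM
compound 2, `N#CC1CN1C(=O)Nc1ccc(Cl)c(Cl)c1`: 7200 nM
compound 3, `N#CC1CN1C(=O)NCc1ccccc1`: 10000 nM

Of the compounds shown here, three sharing the same core have been tested in a functional assay on L1210 cells (Mus musculus) for inhibition, read by MTT assay; a lower number here means a stronger inhibitor, a higher number a weaker inhibitor. Compound 1 gives 9700 nM, the second highest of the three numbers. Its nearest neighbour is compound 3, which gives 10000 nM, a gap within the usual scatter of repeated measurements. Compound 2 gives 7200 nM, and this gap to compound 1 also lies within the scatter. No pair among these three therefore separates beyond what repeated runs would show, and none of them can be called the stronger or the weaker inhibitor on this evidence.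

The next compound, compound 4, `N#CC1CN1C(=O)Nc1ccc(S(N)(=O)=O)cc1`, is not yet measured in this assay. It differs from compound 1 in one place: sulfamoyl in place of ethoxycarbonyl on an aromatic carbon. The whole rest of the molecule is kept.

Since compounds 1, 2 and 3 cluster closely despite carrying quite different groups on the aromatic ring or a different linker, the expected step for compound 4 is small. The step from compound 1 to compound 4 is estimated at a 1.1-fold lower number from compound 1 to compound 4 (0.03 log units; within the scatter), most likely within the scatter, with no clear direction. Compound 4 is expected to give 9000 nM in this assay, between 4000 nM and 20000 nM.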

Compound 4, half-maximal inhibitory concentration: > 38000 nM
Compound 4: no number, only a limit; the forecaster's own chance of this, stated with the estimate: 20%; at least 4.2-fold (0.62 log units) between middle value and limit.
By their numbers in this assay, from the lowest: compounds 2, 1 and 3 (each within the scatter of the next). At a limit, above all of these: compound 4.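

In this assay, the aromatic carbon that carries ethoxycarbonyl in compound 1, para to a group of 8 heavy atoms, proves sensitive to what sits on it: sulfamoyl in its place gives an at least 3.9-fold higher number from compound 1 to compound 4 (0.59 log units; beyond the scatter). Compound 4 has a limit and no number, so the step has a lower bound but no known upper end: the limit of > 38000 nM in this assay, at which 1 of the 4 values shown sits. Among the compounds shown here, the values of compounds 1, 2 and 3 all lie within the scatter of each other and offered no step between compounds differing in one place, so this exchange is the first sign that the group on this carbon can matter.

The single exchange leaves open which part of the change counts, as sulfamoyl brings a nitrogen, a sulfur and a hydrogen-bond donor at once, and the compounds shown cannot separate these. A methylsulfonyl group on the same carbon would keep the sulfur without the nitrogen, while a carboxylic acid or an amine there would show whether the loss follows sulfamoyl alone or extends to other replacements of ethoxycarbonyl.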